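Compound 4 and a series resting on one number

The source may report more compounds than this note shows. Statements on the series, on what has been measured and on what is new or still open speak of the compounds shown alone.

Measured in a functional assay on MCF7 cells (Homo sapiens), read by MTT assay, with a stated time of 48 h; a lower number here means a stronger inhibitor, a higher number a weaker inhibitor:
- compound 1 `CCN(CC)CCCNC(=O)c1ccc(C(CC)(CC)c2ccc(OCC(O)C(C)(C)C)c(C)c2)n1CC`: 190 nM
- compound 2 `CCn1c(C(=O)NCC(OC)OC)ccc1C(CC)(CC)c1ccc(OCC(O)C(C)(C)C)c(C)c1`: > 50000 nM
- compound 3 `C#CC(C)OC(=O)c1ccc(C(CC)(CC)c2ccc(OCC(O)C(C)(C)C)c(C)c2)n1CC`: > 50000 nM

Compound 3 gives only a limit, > 50000 nM, and no number. Compound 2 also gives only a limit, > 50000 nM. The series thus shows (the limit of > 50000 nM in this assay, at which 2 of the 3 values shown sit). Among the compounds with values here, compound 1, at 190 nM, is the only one with a true number.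

Compound 4 `CC[C@@H](C)[C@H](NC(=O)c1ccc(C(CC)(CC)c2ccc(OCC(O)C(C)(C)C)c(C)c2)n1CC)C(=O)O` keeps the shared core and changes one group of compound 3: (1-carboxy-2-methylbutyl)amino in place of (1-methylprop-2-yn-1-yl)oxy on a carbonyl carbon.

Within the data shown here, three measured steps bear on this. Replacing the side chain of compound 1 gives an at least 260-fold higher number from compound 1 to compound 3 (2.42 log units; beyond the scatter). A second replacement, which keeps an amino group on the carbonyl carbon, gives an at least 260-fold higher number from compound 1 to compound 2 (2.42 log units; beyond the scatter). Both steps are large, so an amino group there did not by itself preserve the activity of compound 1. The third is a step that the two limits leave unreadable from compound 2 to compound 3.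

Compound 4 lacks the 3-(diethylamino)propyl chain of compound 1, so it is expected to stay close to compound 3, with no readable gain in this assay. The expected step is an at least 1.4-fold lower number from compound 3 to compound 4 (0.15 log units; that floor lies within the scatter). A report of only a limit is the likeliest outcome. For compound 4 the estimated value is 35000 nM, within an expected range of 8000 nM to 100000 nM.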

Compound 4, half-maximal inhibitory concentration: 2000 nM
Beside the measured number, compound 4's estimate is 18-fold (1.24 log units) above it, outside the stated range (below it).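

In this assay, the change at this carbonyl carbon gives an at least 25-fold lower number from compound 3 to compound 4 (1.39 log units; beyond the scatter), and the change on the amide-type nitrogen gives an at least 25-fold lower number from compound 2 to compound 4 (1.39 log units; beyond the scatter), so compound 4 shows that a readable value in this series does not require the 3-(diethylamino)propyl chain of compound 1. The amide link alone does not settle the outcome, as compound 2 and compound 4 share it and differ in the group on that nitrogen, yet 1-carboxy-2-methylbutyl does not fully take the place of 3-(diethylamino)propyl, with an 11-fold higher number from compound 1 to compound 4 (1.02 log units; beyond the scatter). The steps from compound 2 and compound 3 are floors and not exact sizes, as each of these two compounds gives a limit and no true number: the limit of > 50000 nM in this assay, at which 2 of the 4 values shown sit.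

The compounds shown do not separate the contribution of the carboxylic acid from that of the branched 2-methylbutyl chain, and a methyl ester or a primary amide in place of the acid would bear on that question. They also leave open whether the two defined stereocentres matter, and whether an amine on a shorter chain would come closer to compound 1.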